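A few compounds are considered here, and "the series" means these few. Any claim that something is new, unique, unknown or untested is made for them only; others in the source may bear on it.

In a functional assay on Bel7402/5-FU cells (Homo sapiens) for antiproliferative activity, read by MTT assay, with a stated time of 72 h (a lower number here means a stronger inhibitor, a higher number a weaker inhibitor), compound 3 `C=C1C(=O)O[C@H]2[C@H]1CC/C(COC(=O)Cn1cc(F)c(=O)n(Cc3ccc([N+](=O)[O-])cc3)c1=O)=C\CC[C@@]1(C)O[C@@H]21` gives 4340 nM. This lies within the scatter of compound 1 `C=C1C(=O)O[C@H]2[C@H]1CC/C(COC(=O)Cn1cc(F)c(=O)n(Cc3ccccc3)c1=O)=C\CC[C@@]1(C)O[C@@H]21` at 4270 nM, whereas compound 2 `C=C1C(=O)O[C@H]2[C@H]1CC/C(COC(=O)CCC(=O)NCCCCCCNC(=O)Cn1cc(F)c(=O)n(Cc3ccccc3)c1=O)=C\CC[C@@]1(C)O[C@@H]21` shows a clearly higher number, 16200 nM. The next compound is compound 4 `C=C1C(=O)O[C@H]2[C@H]1CC/C(COC(=O)Cn1cc(F)c(=O)n(Cc3cc(F)ccc3F)c1=O)=C\CC[C@@]1(C)O[C@@H]21`, with 2,5-difluorophenyl in place of 4-nitrophenyl on a saturated chain carbon bound to an aromatic nitrogen. Among the compounds with values here, only one measured step bears on this group, nitro in place of hydrogen on an aromatic carbon, and it is a 1.0-fold higher number from compound 1 to compound 3 (0.01 log units; within the scatter). Within the data shown here, no compound with fluorine on this ring has been measured, so no change beyond the scatter is expected in this assay. The expected step is a 1.1-fold lower number from compound 3 to compound 4 (0.04 log units; within the scatter). Compound 4 is estimated at 4000 nM, with an expected range of 1800 nM to 9000 nM.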

Compound 4, half-maximal inhibitory concentration: 4610 nM
Compound 4: the middle estimate sits 1.2-fold (0.06 log units) below what was measured, within the range that was stated.
By their numbers in this assay, from the lowest: compounds 1, 3 and 4 (each within the scatter of the next); then compound 2.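

In this assay, the group on the saturated chain carbon bound to an aromatic nitrogen can now carry two fluorines as well: 2,5-difluorophenyl replaces 4-nitrophenyl with a small step (a 1.1-fold higher number from compound 3 to compound 4 (0.03 log units; within the scatter)) and replaces phenyl with another (a 1.1-fold higher number from compound 1 to compound 4 (0.03 log units; within the scatter)), both within the scatter. Phenyl, 4-nitrophenyl and 2,5-difluorophenyl thus give numbers within the scatter of one another, extending what the single nitro step showed to a ring with two substituents. Nothing available explains this lack of change.

As far as these compounds go, whether an amine or a carboxylic acid on this ring would move the number remains open. So does whether a longer chain in place of the benzyl carbon would do so.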